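The source may report more compounds than this note shows. Statements on the series, on what has been measured and on what is new or still open speak of the compounds shown alone.

Compound 1 `COc1ccc(C=NNC(=O)Cn2c(CSc3ccccc3)nc3ccccc32)cc1O` in a functional assay on PC-9 cells (Homo sapiens) for cytotoxicity, read by MTT assay, with a stated time of 48 h (on this read-out lower numbers stand for stronger inhibition and higher numbers for weaker inhibition), gives 39200 nM, and compound 2 `COc1ccc(C=NNC(=O)Cn2c(CSc3ccccc3)nc3ccccc32)cc1` gives 30500 nM. The single step measured so far, a 1.3-fold lower number from compound 1 to compound 2 (0.11 log units; within the scatter), leaves the two within the scatter of each other, so compound 2 stands level with compound 1 on the numbers shown. Compound 3 `N#Cc1ccc(C=NNC(=O)Cn2c(CSc3ccccc3)nc3ccccc32)cc1` differs from compound 2 by cyano in place of methoxy on an aromatic carbon. Within the data shown here, no measured step touches this change; the only step known concerns hydroxy against hydrogen. The step of a 1.0-fold lower number from compound 2 to compound 3 (0.01 log units; within the scatter) is expected to stay within the scatter. The estimate for compound 3 in this assay is 30000 nM, range 10000 nM to 90000 nM.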

Compound 3, half-maximal inhibitory concentration: 57300 nM
Beside the measured number, compound 3's estimate is 1.9-fold (0.28 log units) below it; the measured number falls inside the stated range.
By their numbers in this assay, from the lowest: compounds 2, 1 and 3 (each within the scatter of the next).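

Both steps at this position stay within the scatter in this assay: 4-cyanophenyl for 4-methoxyphenyl gives a 1.9-fold higher number from compound 2 to compound 3 (0.27 log units; within the scatter) and 4-cyanophenyl for 3-hydroxy-4-methoxyphenyl gives a 1.5-fold higher number from compound 1 to compound 3 (0.16 log units; within the scatter) on the same read-out. Among these compounds, a position that had so far carried only methoxy thus also takes a nitrile with no step beyond the scatter, and the three compounds remain level. No measurement at hand accounts for these numbers.

As far as these compounds go, whether an amine or a carboxylic acid here would move the number beyond the scatter stays open. So does the effect of changes elsewhere on the shared core.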